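A few compounds are considered here, and "the series" means these few. Any claim that something is new, unique, unknown or untested is made for them only; others in the source may bear on it.

Measured in a functional assay on the whole organism with Rattus norvegicus as the target; a lower number here means that less compound is needed, a higher number that more compound is needed for the effect:
- compound 1 `CCOCCOC(=O)C(=O)Nc1nc(-c2cc(Br)no2)cs1`: 11 mg/kg
- compound 2 `CCOC(=O)C(=O)Nc1nc(-c2cc(Br)no2)cs1`: 12 mg/kg
- compound 3 `CCOC(=O)C(=O)Nc1nc(-c2cc(C)no2)cs1`: 0.2 mg/kg

Compound 3 has the lowest number of the three in this assay, and it lies beyond the scatter from both other compounds. Compound 4 `Cc1cc(-c2csc(NC(=O)C(=O)O)n2)on1` keeps the methyl of compound 3 and alters the ester, with hydrogen in place of ethyl on an oxygen next to a carbonyl group, that is, ethoxycarbonyl to carboxy (hydrogen in place of ethyl on an oxygen next to a carbonyl group).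

For the measured compounds named here, no measured pair covers this change directly. The closest evidence is a 1.1-fold higher number from compound 1 to compound 2 (0.04 log units; within the scatter), which also alters the chain on that oxygen. However, that step keeps the ester, and both of its compounds carry bromo, so it offers only weak support for a small effect. The other measured step, a 60-fold lower number from compound 2 to compound 3 (1.78 log units; beyond the scatter), lies at a different place and does not predict the direction here, but it shows that single changes in this series can be large. A modest rise is therefore expected, with wide uncertainty in either direction. The expected change is a 2.0-fold higher number from compound 3 to compound 4 (0.30 log units; within the scatter). For compound 4 the estimated value is 0.4 mg/kg, with an expected range of 0.05 mg/kg to 4 mg/kg.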

Compound 4, dose for half-maximal effect: 0.3 mg/kg
Estimate against measurement, compound 4: 1.3-fold (0.12 log units) above, and the stated range covers the measured number.
By their numbers in this assay, from the lowest: compounds 3 and 4 (each within the scatter of the next); then compounds 1 and 2 (each within the scatter of the next).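

In this assay, hydrogen in place of ethyl on an oxygen next to a carbonyl group, that is, ethoxycarbonyl to carboxy, gives a 1.5-fold higher number from compound 3 to compound 4 (0.18 log units; within the scatter), so with methyl on the aromatic carbon this position tolerates loss of the ester without a change beyond the scatter. The earlier step at this position, a 1.1-fold higher number from compound 1 to compound 2 (0.04 log units; within the scatter), only shortened the chain within the ester and was read on bromo compounds, so it left open whether the ester itself could go. Compounds 3 and 4 now show that ethyl and hydrogen on this oxygen both fit the low end of the series, well apart from the bromo esters, and no data at hand explain this result.

From the compounds shown here alone, the effect of bromo against methyl is known only for the esters, so it remains open whether the large gap seen there would also appear with a carboxy group at this position. Also open, going by these compounds, is how this assay responds to an amide in place of the carboxy, or to a longer chain such as propyl on the oxygen next to a carbonyl group.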